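The source may hold more compounds than are shown below. What is called first, only, known or untested is meant among the compounds shown, and "the series" means these compounds.

Compound 2 `Cc1nc(-c2ccccc2)c(C(=O)N2CCN(c3cccc(Cl)c3Cl)CC2)o1` stands highest of the three numbers seen so far. In a functional assay on HL-60 cells (Homo sapiens) for inhibition, read by MTT assay, with a stated time of 72 h (on this read-out lower numbers stand for stronger inhibition and higher numbers for weaker inhibition), compound 2 gives 133 nM. Compound 3 `COc1cccc(N2CCN(C(=O)c3oc(C)nc3-c3ccc(F)cc3)CC2)c1` gives 112 nM, which lies within the scatter of compound 2, while compound 1 `COc1cc(OC)cc(N2CCN(C(=O)c3oc(C)nc3-c3cccc(F)c3)CC2)c1` gives 28.2 nM, a gap beyond the scatter. Compound 4 `Cc1nc(-c2ccccc2)c(C(=O)N2CCN(c3ccccc3F)CC2)o1` has not yet been measured; it differs from compound 2 in one place, (2-fluorophenyl in place of 2,3-dichlorophenyl on an amine nitrogen in a ring). For the measured compounds named here, no measured pair shows this change, and the other two compounds carry unrelated groups on that ring nitrogen, so they offer no guide. The account therefore expects only a small step, if any, toward a higher number, not beyond the scatter, as a 1.5-fold higher number from compound 2 to compound 4 (0.18 log units; within the scatter). Compound 4 is estimated at 200 nM, within a range from 60 nM to 700 nM.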

Compound 4, half-maximal inhibitory concentration: 147 nM
Beside the measured number, compound 4's estimate is 1.4-fold (0.13 log units) above it; the measured number falls inside the stated range.
By their numbers in this assay, from the lowest: compound 1; then compounds 3, 2 and 4 (each within the scatter of the next).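

In this assay, for the compounds shown here, the first measured single change at this position gives a 1.1-fold higher number from compound 2 to compound 4 (0.04 log units; within the scatter) when 2-fluorophenyl takes the place of 2,3-dichlorophenyl on the amine nitrogen in the ring. Compound 2 and compound 4 therefore cannot be told apart in this read-out, although the change alters the halogen substitution and removes one heavy atom. Nothing available explains this result.

The step compares only these two halogen-bearing phenyl groups. It leaves open whether a benzyl group or a pyridine ring on that nitrogen would keep the number within the scatter.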